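A few compounds are considered here, and "the series" means these few. Any claim that something is new, unique, unknown or untested is made for them only; others in the source may bear on it.

Measured so far in an in vitro assay on HEK-tsA201 cells for antagonist activity at Neuronal acetylcholine receptor; alpha3/beta4 (Homo sapiens), read by fluorescence and calcium flux; on this read-out higher numbers stand for weaker inhibition and lower numbers for stronger inhibition:
compound 1 `C#CCOc1ccc(C(=O)Nc2cccc(C)n2)cc1` gives 21700 nM
compound 2 `C=CCOc1ccc(C(=O)Nc2ccccn2)cc1` gives 61400 nM
compound 3 `CCCOc1ccc(C(=O)Nc2cccc(Br)n2)cc1` gives only a limit, > 100000 nM

Compound 3 stands at the weak end of what is shown: its result is a limit of the assay and not a number, and (the limit of > 100000 nM in this assay, at which 1 of the 3 values shown sits). Compound 1 and compound 2 each return a numerical value in this assay, compound 1 the lower of the two, and neither is a strong inhibitor on this read-out.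

Compound 4 `CCCOc1ccc(C(=O)Nc2cccc(Nc3cccc(F)c3)n2)cc1` is not yet measured. It differs from compound 3 in one place: (3-fluorophenyl)amino in place of bromo on an aromatic carbon. Going by the values given here, no measured pair in the set follows an exchange of this kind, so the direction of the step cannot be read from neighbours. The change is large enough that a step beyond the scatter in either direction is plausible; with compound 3 at the limit, a recorded number for compound 4 would by itself mean stronger inhibition, while a second limit remains a real possibility.

Compound 4 is expected near 60000 nM, in the range 10000 nM to 200000 nM. The expected step is an at least 1.6-fold lower number from compound 3 to compound 4 (0.22 log units; that floor lies within the scatter).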

Compound 4, half-maximal inhibitory concentration: > 100000 nM
Compound 4 gave a limit, no number (the forecaster's own chance of this, stated with the estimate: 45%); middle value at least 1.6-fold (0.22 log units) away from the limit.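

In this assay compound 3 and compound 4 both return a limit and not a number, so no step between them can be read: the limit of > 100000 nM in this assay, at which 2 of the 4 values shown sit.

The compounds shown leave open whether (3-fluorophenyl)amino in place of bromo shifts inhibition in either direction.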